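The source may report more compounds than this note shows. Statements on the series, on what has been measured and on what is new or still open speak of the compounds shown alone.

Measured compounds:
- compound 1 `CCOc1ccccc1NC(=O)CSc1c[nH]c2c(Br)c(OC)ccc12` — in an ADME assay on HEK-293T cells (Homo sapiens) for cytotoxicity, read by CCK-8 assay, with a stated time of 48 h (on this read-out higher numbers stand for lower toxicity in this test and lower numbers for higher toxicity in this test), compound 1 gives > 100000 nM
- compound 2 `CCOc1ccccc1NC(=O)CSc1c[nH]c2c(OC)cccc12` — in this assay compound 2 gives > 100000 nM

Compound 1 stands only at a limit of this assay: the value reported for compound 1 is a limit, not a number, and says only that no half-maximal cytotoxic concentration was reached. The same holds for compound 2, whose value is likewise a limit. Within the data shown here, the sole piece of evidence is therefore (the limit of > 100000 nM in this assay, at which 2 of the 2 values shown sit), and no step between two measured compounds can be drawn from these numbers.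

The unmeasured compound 3 `CCOc1ccccc1NC(=O)CSc1c[nH]c2cc(OC)ccc12` differs from compound 1 by hydrogen in place of bromo on an aromatic carbon. With both measured values sitting at the limit, there is nothing to suggest that this change moves the read-out in either direction. The step that the limit leaves unreadable from compound 1 to compound 3 is expected to be none beyond the scatter. Compound 3 is accordingly expected to show about 150000 nM in this assay, within a range of 60000 nM to 400000 nM, most likely again reported only as a limit.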

Compound 3, half-maximal cytotoxic concentration: 88200 nM
Beside the measured number, compound 3's estimate is 1.7-fold (0.23 log units) above it; the range from low to high includes it.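

In this assay, among these compounds, compound 3 gives 88200 nM, the only one of the three values shown that is a number, so a half-maximal cytotoxic concentration was reached once bromo gave way to hydrogen. Placing hydrogen instead of bromo on this aromatic carbon, which is ortho to a methoxy group and ortho to a fused ring, gives an at least 1.1-fold lower number from compound 1 to compound 3 (0.05 log units; that floor lies within the scatter), so the printed floor alone does not show that this change moves the read-out beyond the scatter. For compound 1 the value > 100000 nM is a limit, which leaves the step with a floor and no measured size, and the comparison rests on this: the limit of > 100000 nM in this assay, at which 2 of the 3 values shown sit.

As far as these compounds go, whether the real difference between bromo and hydrogen at this position is larger than that floor stays open, since the step has no upper end. Also open, from the compounds shown here alone, is how a chloro group, a methyl group or an amine on the same aromatic carbon would read in this assay, and whether a longer chain in place of the ethoxy group would shift the value of compound 3.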